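A few compounds are considered here, and "the series" means these few. Any claim that something is new, unique, unknown or untested is made for them only; others in the source may bear on it.

Working notes on the series, step from compound 3 to compound 4.

For the measured compounds named here, compound 3 `Cc1ccc(-c2cc3c(cn2)ncn3-c2ccc(OC(F)F)cc2)c(C)c1` gives 180 nM in a functional assay on HL-60 cells (Homo sapiens) for activation, read by flow cytometry, with a stated time of 4 days (a lower number here means that less compound is needed, a higher number that more compound is needed for the effect), the second highest of the three numbers measured so far. Compound 1 `COc1cc(F)ccc1-c1cc2c(cn1)ncn2-c1ccc(OC(F)F)cc1` gives 93 nM in this assay, and compound 2 `Cc1cccc(C)c1-c1cc2c(cn1)ncn2-c1ccc(OC(F)F)cc1` gives 980 nM. The step of a 1.9-fold higher number from compound 1 to compound 3 (0.29 log units; within the scatter) lies within the scatter, whereas a 5.4-fold lower number from compound 2 to compound 3 (0.74 log units; beyond the scatter) and an 11-fold higher number from compound 1 to compound 2 (1.02 log units; beyond the scatter) lie beyond it. Compound 4 `Cc1cc(O)ccc1-c1cc2c(cn1)ncn2-c1ccc(OC(F)F)cc1` is not yet measured.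

The change from compound 3 to compound 4 is hydroxy in place of methyl on an aromatic carbon. Going by the values given here, no measured step involves a hydroxy group, so there is no direct precedent. The closest comparison is a 1.9-fold higher number from compound 1 to compound 3 (0.29 log units; within the scatter), which also alters the substitution of that aromatic ring without a shift beyond the scatter, which suggests the series tolerates changes of this kind at the 4-position of the pendant ring. The large step of a 5.4-fold lower number from compound 2 to compound 3 (0.74 log units; beyond the scatter) concerns the 2,6-dimethylphenyl to 2,4-dimethylphenyl change and does not bear on a hydroxy for methyl exchange. The step of a 1.2-fold higher number from compound 3 to compound 4 (0.09 log units; within the scatter) is therefore expected to be small, with the direction uncertain and a wide range allowed.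

Compound 4 is estimated at 220 nM, with a range from 70 nM to 700 nM.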

Compound 4, half-maximal effective concentration: 890 nM
Beside the measured number, compound 4's estimate is 4.0-fold (0.61 log units) below it; the whole stated range lies below it.
By their numbers in this assay, from the lowest: compounds 1 and 3 (each within the scatter of the next); then compounds 4 and 2 (each within the scatter of the next).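

Hydroxy in place of methyl on this carbon, para to a large group and meta to a methyl group, is not a silent exchange: a 4.9-fold higher number from compound 3 to compound 4 (0.69 log units; beyond the scatter) shows that the tolerance suggested by the earlier compounds does not extend to this change. The second reading, a 1.1-fold lower number from compound 2 to compound 4 (0.04 log units; within the scatter), means that the 4-hydroxy-2-methylphenyl group cannot be told apart from the 2,6-dimethylphenyl group on this number, while a 9.6-fold higher number from compound 1 to compound 4 (0.98 log units; beyond the scatter) leaves it clearly separated from the 4-fluoro-2-methoxyphenyl group. Nothing at hand accounts for this shift.

On these data alone, whether the shift is particular to hydroxy stays open, and an amine, a methoxy group or a carboxylic acid on the same carbon would each give a further reading of how this place responds. Also open, as far as these compounds go, is whether hydroxy on this carbon gives a step of similar size when the methyl group of the 4-hydroxy-2-methylphenyl group is exchanged for the methoxy group found in compound 1.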